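Variation on the imine carbon: compound 3 to compound 4

A few compounds are considered here, and "the series" means these few. Any claim that something is new, unique, unknown or untested is made for them only; others in the source may bear on it.

Measured so far in an assay on isolated protein for inhibition of Maltase-glucoamylase (Homo sapiens), with a stated time of 15 min; on this read-out lower numbers stand for stronger inhibition and higher numbers for weaker inhibition:
- compound 1 `O=C(N/N=C/c1ccccc1O)c1ccc(-c2nc3ccccc3s2)cc1` gives 5550 nM
- compound 2 `O=C(N/N=C/c1ccc(O)cc1O)c1ccc(-c2nc3ccccc3s2)cc1` gives 5580 nM
- compound 3 `COc1cc(/C=N/NC(=O)c2ccc(-c3nc4ccccc4s3)cc2)ccc1O` gives 53300 nM

Compound 3 gives the highest number of the three, and both other compounds lie well apart from it. Compound 1 and compound 2 sit together, the step of a 1.0-fold higher number from compound 1 to compound 2 (0.00 log units; within the scatter) lying within the scatter. The two steps into compound 3, a 9.6-fold higher number from compound 1 to compound 3 (0.98 log units; beyond the scatter) and a 9.6-fold higher number from compound 2 to compound 3 (0.98 log units; beyond the scatter), are of the same size, modest and beyond the scatter.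

Compound 4 `O=C(N/N=C/c1cc(O)ccc1O)c1ccc(-c2nc3ccccc3s2)cc1` differs from compound 3 in one place: 2,5-dihydroxyphenyl in place of 4-hydroxy-3-methoxyphenyl on a carbon with a double bond to nitrogen. The entering group, like the groups of compound 1 and compound 2, carries only hydroxy substituents and no methoxy, so the two steps into compound 3 are the ones that bear on this change, and the change runs the other way, from the group of compound 3 back towards groups of the kind found in compound 1 and compound 2. For the measured compounds named here, a lower number in this assay is therefore expected, roughly of the size seen in those two steps, with some added uncertainty since no measured pair involves a 2,5-dihydroxyphenyl group.

For compound 4 a value of 6500 nM is estimated, with a range from 2500 nM to 17000 nM, which means an expected step of an 8.2-fold lower number from compound 3 to compound 4 (0.91 log units; beyond the scatter).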

Compound 4, half-maximal inhibitory concentration: 11900 nM
Compound 4: middle estimate off by 1.8-fold (0.26 log units), on the low side, within the range that was stated.
By their numbers in this assay, from the lowest: compounds 1 and 2 (each within the scatter of the next); then compound 4; then compound 3.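

In this assay, the step of a 4.5-fold lower number from compound 3 to compound 4 (0.65 log units; beyond the scatter) shows that 2,5-dihydroxyphenyl on this carbon regains much of the ground lost with 4-hydroxy-3-methoxyphenyl, but not all of it: a 2.1-fold higher number from compound 2 to compound 4 (0.33 log units; beyond the scatter) and a 2.1-fold higher number from compound 1 to compound 4 (0.33 log units; beyond the scatter) both lie beyond the scatter, though they are small. The earlier compounds shown here showed a second hydroxy making no difference within the scatter, as in a 1.0-fold higher number from compound 1 to compound 2 (0.00 log units; within the scatter), whereas compound 4 shows that among the three compounds carrying only hydroxy substituents, the outcome depends on which dihydroxyphenyl group is present, with 2,5-dihydroxyphenyl giving the higher number of the two dihydroxyphenyl groups. Nothing at hand bears on the reason for these differences.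

Compound 3 and compound 4 differ in both the methoxy and the arrangement of the hydroxy groups, so the compounds shown do not separate the contribution of the methoxy from that of the hydroxy arrangement. Also open, from the compounds shown here alone, is whether this carbon accepts a 3,4-dihydroxyphenyl, 2-methoxyphenyl or 2-aminophenyl group, or a phenyl group bearing a carboxylic acid, on the same core.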